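This account rests on a few compounds, and the source may have more. Where it says the series, first, only, none or still open, it means among the compounds named here.

Compound 1 `Cc1ncnc2c1c(-c1cccs1)cn2[C@@H]1O[C@H](CO)[C@@H](O)[C@H]1O` in a functional assay on CEM-DNR-bulk cells (Homo sapiens), read by MTT assay, with a stated time of 72 h (a lower number here means a stronger inhibitor, a higher number a weaker inhibitor), gives > 20000 nM, which is a limit of the assay and not a number. Compound 2 `CSc1ncnc2c1c(-c1cccs1)cn2[C@@H]1O[C@H](CO)[C@@H](O)[C@H]1O` in this assay gives > 20000 nM, again only a limit. The step that the two limits leave unreadable from compound 1 to compound 2 is not readable, and compound 2 stands at the limit of > 20000 nM in this assay, at which 2 of the 2 values shown sit. Compound 3 `CN(C)c1ncnc2c1c(-c1cccs1)cn2[C@@H]1O[C@H](CO)[C@@H](O)[C@H]1O` differs from compound 2 by dimethylamino in place of methylsulfanyl on an aromatic carbon. For the measured compounds named here, the one measured step is unreadable, so no measured step bears on this change. Compound 3 is expected to remain at the limit, estimated at 20000 nM with a range of 5000 nM to 80000 nM. The expected step of a number no higher from compound 2 to compound 3 (the limit leaves the size open) is taken as none beyond the scatter.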

Compound 3, half-maximal inhibitory concentration: > 20000 nM
Compound 3 was reported as a limit (the forecaster's own chance of this, stated with the estimate: 80%); the middle value lies on the limit itself.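

No step can be read among compound 1, compound 2 and compound 3, since each result is only a limit of the assay: the limit of > 20000 nM in this assay, at which 3 of the 3 values shown sit. The compounds shown leave open whether any group at this place on the shared core gives a measurable value in this assay.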